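Aryl acid swap on a cyclopentyl ketone modulator

A few compounds are considered here, and "the series" means these few. Any claim that something is new, unique, unknown or untested is made for them only; others in the source may bear on it.

Compound 1 `Cc1c(OCCCCOc2ccc(C(=O)O)cc2Cl)ccc(C(=O)CC2CCCC2)c1O`: 27.4%
Compound 2 `Cc1c(OCCCCOc2cccc(C(=O)O)c2)ccc(C(=O)CC(C)C)c1C`: 18.3%
Compound 3 `Cc1c(OCCCCOc2ccc(C(=O)O)cc2Cl)ccc(C(=O)CC(C)C)c1O`: 62.9%

In an assay on HEK293 cells for positive allosteric modulation of metabotropic glutamate receptor 3 (Rattus norvegicus), read by thallium flux, with a stated time of 2.5 min (a higher number here means a larger maximal response, a lower number a smaller maximal response), compound 1 gives 27.4%, which sits well under compound 3 at 62.9%; compound 2 at 18.3% lies within the scatter of compound 1. Going by the values given here, the only measured step, a number 35.5 percentage points higher from compound 1 to compound 3 (beyond the scatter), concerns the saturated chain carbon bound to the carbonyl carbon and says nothing about the aryl acid. Compound 4 `Cc1c(OCCCCOc2ccc(F)c(C(=O)O)c2)ccc(C(=O)CC2CCCC2)c1O` differs from compound 1 by 3-carboxy-4-fluorophenyl in place of 4-carboxy-2-chlorophenyl on an oxygen on a saturated carbon. Among the compounds with values here, no measured step touches this position, so the expectation is for a change of little size. Compound 4 is expected to give 26%, between 10% and 50%, a step of a number 1.4 percentage points lower from compound 1 to compound 4 (within the scatter) that is expected to stay within the scatter.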

Compound 4, largest response reached (reported as percent of maximum), in percent of the reference or control that the assay uses: 98.4%
Estimate against measurement, compound 4: 72.4 percentage points below; measured number outside the range, above it.
By their numbers in this assay, from the lowest: compounds 2 and 1 (each within the scatter of the next); then compound 3; then compound 4.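

The group on the oxygen on a saturated carbon turns out to govern the maximal response in this assay as well: replacing 4-carboxy-2-chlorophenyl with 3-carboxy-4-fluorophenyl gives a number 71 percentage points higher from compound 1 to compound 4 (beyond the scatter). The two groups have the same heavy-atom, donor and acceptor counts, so the step arises without any change in those counts. No evidence on hand accounts for it. The compounds shown leave open whether the halogen or the place of the carboxy group carries the step, which a 3-carboxy-4-chlorophenyl group could separate. As far as these compounds go, whether 3-carboxy-4-fluorophenyl acts alike with isopropyl in place of cyclopentyl also remains open.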